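Changing the group on the sulfonamide nitrogen of a cyclic core

A few compounds are considered here, and "the series" means these few. Any claim that something is new, unique, unknown or untested is made for them only; others in the source may bear on it.

Measured so far in a functional assay on CCRF-CEM cells (Homo sapiens) for cytotoxicity; a lower number here means that less compound is tolerated, a higher number that more compound is tolerated:
Compound 1 `O=C1c2ccccc2N(COCc2ccccc2)S(=O)(=O)N1Cc1ccccc1` gives 25 ug/mL.
Compound 2 `O=C1c2ccccc2NS(=O)(=O)N1Cc1ccccc1` reaches only a limit of the assay, > 200 ug/mL.
Compound 3 `CC(=O)OCCOCN1c2ccccc2C(=O)N(Cc2ccccc2)S1(=O)=O` gives 103 ug/mL.

Among the two numbers that are not limits, compound 3 stands highest; its nearest neighbour is compound 1, and the step is a 4.1-fold higher number from compound 1 to compound 3 (0.61 log units; beyond the scatter). Removing the whole chain from the sulfonamide nitrogen gave an at least 8.0-fold higher number from compound 1 to compound 2 (0.90 log units; beyond the scatter), while adding the acetoxy-bearing chain back onto compound 2 gave an at least 1.9-fold lower number from compound 2 to compound 3 (0.28 log units; that floor lies within the scatter).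

Compound 4 `C#CCOCN1c2ccccc2C(=O)N(Cc2ccccc2)S1(=O)=O` has not yet been measured. It differs from compound 3 as follows: ethynyl in place of acetoxymethyl on a saturated chain carbon bound to an oxygen on a saturated carbon. Among the measured compounds shown here, the one measured step at the same place is a 4.1-fold higher number from compound 1 to compound 3 (0.61 log units; beyond the scatter), where a phenyl was traded for acetoxymethyl and the number rose. Compound 4 moves back toward a small hydrocarbon end on that chain, closer in kind to compound 1 than to compound 3, so a step downward from compound 3 is expected, though one smaller than a 4.1-fold higher number from compound 1 to compound 3 (0.61 log units; beyond the scatter). The expected step is a 1.7-fold lower number from compound 3 to compound 4 (0.23 log units; within the scatter). For compound 4 the estimate is 60 ug/mL, with a range from 25 ug/mL to 160 ug/mL.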

Compound 4, half-maximal cytotoxic concentration: 23 ug/mL
The estimate for compound 4 lay 2.6-fold (0.42 log units) above the measured number; measured number below the stated range.
By their numbers in this assay, from the lowest: compounds 4 and 1 (each within the scatter of the next); then compound 3. At a limit, above all of these: compound 2.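

In this assay, the end of the chain on the sulfonamide nitrogen proves to matter on its own, since ethynyl in place of acetoxymethyl gives a 4.5-fold lower number from compound 3 to compound 4 (0.65 log units; beyond the scatter), whereas ethynyl in place of phenyl at the same place gives a 1.1-fold lower number from compound 1 to compound 4 (0.04 log units; within the scatter), so the two hydrocarbon ends cannot be told apart and only the acetoxymethyl end of compound 3 stands away from them. The (propargyloxy)methyl chain in place of hydrogen on that nitrogen gives an at least 8.6-fold lower number from compound 2 to compound 4 (0.93 log units; beyond the scatter), which shows that a chain with a short hydrocarbon end matches the step seen with the (benzyloxy)methyl chain of compound 1, and not the smaller step with the acetoxy-bearing chain. Compound 2 stands at a limit of the assay, so this step is only a floor: the limit of > 200 ug/mL in this assay, at which 1 of the 4 values shown sits.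

Going by these compounds, it remains open whether the higher number of compound 3 goes with the acetoxy end as such or with any oxygen-bearing end, a question that a hydroxyl, an amine or a carboxylic acid at the end of the chain would address. On these data alone, it is also open whether the close agreement of compound 1 and compound 4 would hold for a longer saturated hydrocarbon chain.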